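Bromo for Fluoro on the Aryl Ketone of Compound 1

The compounds below may be only part of what the source reports. "The series", "measured", "known", "first", "only" and "open" are said of these compounds alone.

Compound 1 `CCOC(=O)c1[nH]c(=O)c(C#N)cc1C(=O)c1ccc(F)cc1`: < 100000 nM in an ADME assay on J774.A1 cells (Mus musculus) for cytotoxicity, read by MTT assay, with a stated time of 48 h; on this read-out higher numbers stand for lower toxicity in this test and lower numbers for higher toxicity in this test
Compound 2 `O=C(c1ccc([N+](=O)[O-])cc1)c1cc(C(=O)O)c(=O)[nH]c1C(=O)O`: 388000 nM

Compound 1 carries a fluorine on its aryl ketone. In this assay compound 1 gives only a limit, < 100000 nM, and not a number. Compound 2, built on the same core with a nitro group and two carboxylic acids, gives 388000 nM in this assay. The two compounds differ in several places, so their values are reported side by side without a step between them. Where compound 1 sits is known only as far as the limit of < 100000 nM in this assay, at which 1 of the 2 values shown sits.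

Compound 3 `CCOC(=O)c1[nH]c(=O)c(C#N)cc1C(=O)c1ccc(Br)cc1` is compound 1 with a single change: bromo in place of fluoro on an aromatic carbon. Among the compounds with values here, with no measured step to lean on and compound 1 known only as a limit, a step that the limit leaves unreadable from compound 1 to compound 3 is expected, that is, none beyond the usual scatter. Compound 3 is therefore estimated at 70000 nM, with a range from 20000 nM to 200000 nM.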

Compound 3, half-maximal cytotoxic concentration: < 100000 nM
Compound 3: only a limit was reported; the forecaster's own chance of this, stated with the estimate: 50%; the middle value is on the limit's open side.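

In this assay compound 3 gives < 100000 nM, which is a limit and not a number. Compound 1 also stands only as a limit, and no step from compound 1 to compound 3 can be read: the limit of < 100000 nM in this assay, at which 2 of the 3 values shown sit.

The compounds shown leave open whether 4-fluorophenyl and 4-bromophenyl give different values in this assay.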